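The source may report more compounds than this note shows. Statements on the series, on what has been measured and on what is new or still open speak of the compounds shown alone.

Compound 1 `CC(C)C[C@@H](N)C(=O)Nc1cc2cc[nH]c(=O)c2cc1Cl` was tested in a functional assay (aorta) with Rattus norvegicus as the target (a lower number here means that less compound is needed, a higher number that more compound is needed for the effect), where compound 1 gives 700 nM. Its mirror-image partner, compound 2 `CC(C)C[C@H](N)C(=O)Nc1cc2cc[nH]c(=O)c2cc1Cl`, shares every atom and bond with it; the fact that compounds 1 and 2 differ only in the configuration as drawn is the only thing that sets the two apart, and for compound 2 the outcome in this assay is "not determined" (no result reported). Compound 3 `CN1CCC(C(=O)Nc2cc3cc[nH]c(=O)c3cc2Cl)CC1` keeps the shared core and the amide but carries 1-methylpiperidin-4-yl on the carbonyl carbon, and in this assay compound 3 gives 250 nM. That single measured step, a 2.8-fold lower number from compound 1 to compound 3 (0.45 log units; beyond the scatter), leaves compound 1 with the highest of the two numbers recorded, its nearest neighbour being compound 3.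

Compound 4 `N[C@H]1CC[C@@H](C(=O)Nc2cc3cc[nH]c(=O)c3cc2Cl)CC1` has not yet been measured. It differs from compound 1 in one place: 4-aminocyclohexyl in place of 1-amino-3-methylbutyl on a carbonyl carbon. Going by the values given here, as in the step to compound 3, the open 1-amino-3-methylbutyl chain gives way to a six-membered non-aromatic ring that still carries one nitrogen, so that step is the only guide, and a modest lowering of similar size seems the most likely outcome, though a result within the scatter cannot be ruled out. Compound 4 is therefore expected to give about 350 nM, with a range from 150 nM to 900 nM. The expected step is a 2.0-fold lower number from compound 1 to compound 4 (0.30 log units; within the scatter).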

Compound 4, half-maximal effective concentration: 180 nM
Compound 4: middle estimate off by 1.9-fold (0.29 log units), on the high side; measured number inside the range.
By their numbers in this assay, from the lowest: compounds 4 and 3 (each within the scatter of the next); then compound 1.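

Compound 4 shows that the lowering seen with compound 3 is not tied to one particular ring: in this assay, replacing the open 1-amino-3-methylbutyl chain with 4-aminocyclohexyl gives a 3.9-fold lower number from compound 1 to compound 4 (0.59 log units; beyond the scatter), again a step beyond the scatter. The two rings hold their nitrogen differently, inside the ring in compound 3 and as an amine on a ring of carbon only in compound 4, yet the comparison gives a 1.4-fold lower number from compound 3 to compound 4 (0.14 log units; within the scatter), so this assay does not separate the two groups. Going by these compounds alone, on this carbonyl carbon, both six-membered rings therefore give lower numbers than the open chain of compound 1, and no compound with a reported number goes against this, although two rings are only a small sample.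

From the compounds shown here alone, whether the nitrogen is needed at all stays open, a question for a plain cyclohexyl group with no amine, and so does the role of configuration, both in the ring of compound 4 and in the pair of compounds 1 and 2. The information available offers no explanation for why either ring gives a lower number than the open chain.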